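Swapping the 3-Methylphenyl for a 4-(Methylsulfonyl)phenyl

The source may hold more compounds than are shown below. What is called first, only, known or untested is meant among the compounds shown, and "the series" means these compounds.

Compound 2 `Cc1cccc(-c2nc3c(c(C)nn3-c3ccccc3)c(-c3ccccc3O)c2C#N)c1` stands highest of the two numbers in a physicochemical assay for solubility, read by spectrophotometry, in phosphate buffer, with a stated time of 18 h, at pH 7.4 (on this read-out lower numbers stand for lower solubility and higher numbers for higher solubility), where compound 2 gives 42000 nM. Its nearest neighbour, compound 1 `CCc1ccc(-c2nc3c(c(C)nn3-c3ccccc3)c(-c3cccc(O)c3)c2C#N)cc1`, gives 18000 nM in this assay, a gap beyond the usual scatter. Compound 3 `Cc1nn(-c2ccccc2)c2nc(-c3ccc(S(C)(=O)=O)cc3)c(C#N)c(-c3ccccc3O)c12` is not yet measured. It differs from compound 2 in one place: 4-(methylsulfonyl)phenyl in place of 3-methylphenyl on an aromatic carbon. Going by the values given here, no pair of measured compounds shows what this change does on its own, so the expectation rests on little. The step from compound 2 to compound 3 is expected to be a 1.9-fold higher number from compound 2 to compound 3 (0.28 log units; within the scatter), a modest rise. Compound 3 is estimated at 80000 nM, with a range from 30000 nM to 200000 nM.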

Compound 3, solubility: 5000 nM
For compound 3 the middle estimate is 16-fold (1.20 log units) above the measured one; the measured number lies below the stated range.
By their numbers in this assay, from the lowest: compound 3; then compound 1; then compound 2.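

In this assay, the position next to the ring nitrogen and ortho to a cyano group proves sensitive to what it carries: 4-(methylsulfonyl)phenyl in place of 3-methylphenyl gives an 8.4-fold lower number from compound 2 to compound 3 (0.92 log units; beyond the scatter), beyond the usual scatter. Going by these compounds alone, this is the first change in one place seen, and the number falls even though the entering group adds hydrogen-bond acceptors. Nothing measured here explains the drop. The compounds shown leave open whether the methylsulfonyl group itself or its place on the phenyl ring matters more, and whether an amine or a carboxylic acid on that ring would raise the number.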